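Piperidine to methylpiperazine on a urea side chain

The compounds below may be only part of what the source reports. "The series", "measured", "known", "first", "only" and "open" are said of these compounds alone.

Measured compounds:
compound 1, `COc1ncc(-c2ccc3nc(NC(=O)NCCN4CCCCC4)sc3c2)cc1NS(=O)(=O)c1ccc(F)cc1`: 750 nM
compound 3, `CCN(CC)CCNC(=O)Nc1nc2ccc(-c3cnc(OC)c(NS(=O)(=O)c4ccc(C)cc4)c3)cc2s1`: 360 nM
compound 2, `CCCNc1nc2ccc(-c3cnc(Cl)c(NS(=O)(=O)c4ccc(F)cc4)c3)cc2s1`: "not determined" (no result reported)

Three compounds share the core of compound 1 and were tested in a functional assay on U-87MG ATCC cells for antiproliferative activity against U-87 MG (Homo sapiens), read by MTT assay, with a stated time of 72 h; on this read-out higher numbers stand for weaker inhibition and lower numbers for stronger inhibition. Compound 1 gives 750 nM, the highest of the two numbers available, so it is the weaker of the two measured compounds. Compound 3 gives 360 nM, a lower number that lies beyond the usual scatter; compound 3 also differs from compound 1 in more than one place, so the two values show a gap but no single cause can be read from them. For compound 2 the entry in this assay reads "not determined" (no result reported), so no number is available for it.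

Compound 4, `COc1ncc(-c2ccc3nc(NC(=O)NCCN4CCN(C)CC4)sc3c2)cc1NS(=O)(=O)c1ccc(F)cc1`, differs from compound 1 in one place: 4-methylpiperazin-1-yl in place of piperidin-1-yl on a saturated chain carbon, two bonds along the chain from an amide-type nitrogen. Among the compounds with values here, no measured pair isolates this change. A ring of the same size with one more hetero atom and one more hydrogen-bond acceptor, on the same saturated chain, is a modest alteration, so the step from compound 1 to compound 4 is expected to stay within the scatter, with a slight lean toward a lower number, giving a 1.3-fold lower number from compound 1 to compound 4 (0.10 log units; within the scatter). Compound 4 is therefore estimated at 600 nM, with a likely range from 250 nM to 1500 nM.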

Compound 4, half-maximal inhibitory concentration: 440 nM
The estimate for compound 4 lay 1.4-fold (0.13 log units) above the measured number; measured number inside the range.
By their numbers in this assay, from the lowest: compounds 3, 4 and 1 (each within the scatter of the next, the first and the last beyond it).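

In this assay, putting 4-methylpiperazin-1-yl in place of piperidin-1-yl on a saturated chain carbon, two bonds along the chain from an amide-type nitrogen, gives a 1.7-fold lower number from compound 1 to compound 4 (0.23 log units; within the scatter). This is the only pair shown that differs in one place, so it is the first direct reading of this position: adding a second ring nitrogen and its methyl group to the end of the urea side chain leaves the number within the normal spread of repeat measurements, and neither ring can be ranked above the other. Nothing measured here bears on what lies behind this result.

As far as these compounds go, it remains open whether a more different group in the same place, such as morpholin-4-yl, a primary amine or a carboxylic acid, or a longer chain carrying either ring, would move the number beyond that spread. One pair also cannot show whether the exchange would read the same way on a compound with a different group elsewhere, such as the 4-methylphenyl sulfonamide of compound 3.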